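A Diethylamino Swap on Compound 1

This account rests on a few compounds, and the source may have more. Where it says the series, first, only, none or still open, it means among the compounds named here.

In a functional assay on HepG2 cells (Homo sapiens) for cytotoxicity, read by MTT assay (a higher number here means a weaker inhibitor, a lower number a stronger inhibitor), compound 1 (`N#Cc1c(F)c(Cl)c2nc(N)nc(N)c2c1F`) gives 4.8 ug/mL. Compound 2 (`N#Cc1c(F)c(F)c2nc(N)nc(N)c2c1F`) gives 5 ug/mL, and a 1.0-fold higher number from compound 1 to compound 2 (0.02 log units; within the scatter) leaves the two level with each other. Compound 3 (`CC(C)(C)Nc1c(C#N)c(F)c2c(N)nc(N)nc2c1F`) gives 16.2 ug/mL, so compound 1 stands with compound 2 at the low end of the three numbers, apart from compound 3.

Compound 4 (`CCN(CC)c1c(C#N)c(F)c2c(N)nc(N)nc2c1Cl`) has not yet been measured. It departs from compound 1 at one place, with diethylamino in place of fluoro on an aromatic carbon, ortho to a chloro group and ortho to a cyano group: diethylamino in place of fluoro on an aromatic carbon.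

For the measured compounds named here, two measured steps bear on this change. The closer one is a 3.2-fold higher number from compound 2 to compound 3 (0.51 log units; beyond the scatter), where (tert-butyl)amino takes the place of fluoro on an aromatic carbon. The other, a 1.0-fold higher number from compound 1 to compound 2 (0.02 log units; within the scatter), suggests that the chloro group kept in compound 4 need not alter that precedent much. Going by the values given here, no measured compound carries diethylamino, so the precedent is only approximate. A modest rise of similar size is therefore expected in this assay, with a wide margin. The expected change is a 3.1-fold higher number from compound 1 to compound 4 (0.49 log units; beyond the scatter). For compound 4 the estimated value is 15 ug/mL, within an expected range from 6 ug/mL to 40 ug/mL.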

Compound 4, half-maximal inhibitory concentration: 2 ug/mL
Estimate against measurement, compound 4: 7.5-fold (0.88 log units) above; measured number below the stated range.
By their numbers in this assay, from the lowest: compound 4; then compounds 1 and 2 (each within the scatter of the next); then compound 3.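

In this assay the replacement of fluoro by diethylamino, on the aromatic carbon ortho to a chloro group and ortho to a cyano group, gives a 2.4-fold lower number from compound 1 to compound 4 (0.38 log units; beyond the scatter) and so runs opposite to the earlier amine step, a 3.2-fold higher number from compound 2 to compound 3 (0.51 log units; beyond the scatter) where (tert-butyl)amino replaced fluoro on the same carbon of the core. Replacing fluoro with an amino group at this position therefore does not move the number in one fixed direction across the compounds shown, and the position tolerates the five heavy atoms of diethylamino without a rise in the number. No measurement offered here accounts for the opposite directions of these two steps.

The two steps differ both in the entering group and in the halogen kept on the neighbouring carbon, so the compounds shown cannot separate these two changes; (tert-butyl)amino alongside chloro and diethylamino alongside fluoro would be the direct comparisons. On these data alone, it also remains open where dimethylamino, dipropylamino or a cyclic amine such as morpholine at this carbon would fall relative to compound 4 and compound 3.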